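The compounds below may be only part of what the source reports. "The series", "measured", "known", "first", "only" and "open" are said of these compounds alone.

Measured so far:
Compound 1, `CC(C)Cc1ccc2c(NCCCNCc3ccco3)ccnc2c1`, gives 4200 nM in a physicochemical assay for solubility, with a stated time of 18 h, at pH 7.4; a higher number here means a more soluble compound, a lower number a less soluble compound.
Compound 2, `COc1cccc(CNCCCNc2ccnc3cc(-c4ccc(C(F)(F)F)cc4)ccc23)c1O`, gives 32000 nM in this assay.

Compound 2 stands highest of the two numbers; its nearest neighbour, compound 1, sits below it by a gap beyond the usual scatter. Within the data shown here, the two structures differ in several places at once, so no single step between them is known. Compound 3, `COc1cccc(CNCCCNc2ccnc3cc(CC4CCCCC4)ccc23)c1O`, has not yet been measured in this assay. It differs from compound 2 in one place: cyclohexylmethyl in place of 4-(trifluoromethyl)phenyl on an aromatic carbon. Among the measured compounds shown here, with no measured step of this kind to lean on, only a small change upward is expected, possibly within the scatter. The step is expected to be a 1.4-fold higher number from compound 2 to compound 3 (0.15 log units; within the scatter). Compound 3 is estimated at 45000 nM, with a range from 14000 nM to 140000 nM.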

Compound 3, solubility: 4200 nM
Beside the measured number, compound 3's estimate is 11-fold (1.03 log units) above it; the measured number lies below the stated range.
By their numbers in this assay, from the lowest: compounds 1 and 3 (each within the scatter of the next); then compound 2.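

In this assay, cyclohexylmethyl in place of 4-(trifluoromethyl)phenyl on this aromatic carbon gives a 7.6-fold lower number from compound 2 to compound 3 (0.88 log units; beyond the scatter), the first single-place step available here. It shows that the group at this position can shift the number beyond the scatter, even though neither group has any hydrogen-bond donors or acceptors. Nothing measured here explains this step.

The change swaps the aromatic ring for a non-aromatic one and also removes the trifluoromethyl, so these two differences remain unseparated. A plain phenyl or a benzyl group on this carbon would help to tell them apart.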